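The source may hold more compounds than are shown below. What is called first, only, known or untested is meant among the compounds shown, and "the series" means these compounds.

Measured so far:
compound 1, `O=C(Nc1cccc(-n2cc(-c3ccncc3)c(-c3cc(O)cc(Cl)c3)n2)c1)Nc1ccc(Cl)c(C(F)(F)F)c1`, -32%
compound 2, `O=C(Nc1cccc(-n2cc(-c3ccncc3)c(-c3cc(O)cc(Cl)c3)n2)c1)Nc1ccc(Cl)c(Cl)c1`, -15%

In a functional assay on SN12C cells (Homo sapiens) for inhibition, read by sulforhodamine B assay, with a stated time of 48 h, tested at 100 uM (a higher number here means a weaker effect of the compound at the concentration tested, a lower number a stronger effect), compound 1 gives -32%, the lowest of the two numbers in hand; compound 2 gives -15%. Going by the values given here, the only step between measured compounds, a number 17 percentage points higher from compound 1 to compound 2 (beyond the scatter), concerns a substituent at the other end of the shared core.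

Compound 3, `COc1cc(Cl)cc(-c2nn(-c3cccc(NC(=O)Nc4ccc(Cl)c(C(F)(F)F)c4)c3)cc2-c2ccncc2)c1`, is not yet measured. It differs from compound 1 in one place: methyl in place of hydrogen on an oxygen on an aromatic ring. Among the compounds with values here, no measured step touches this part of the structure; the available step, a number 17 percentage points higher from compound 1 to compound 2 (beyond the scatter), alters a different group and gives no guide to the size or direction of the present change. With nothing to build on, no step beyond the scatter is expected in this assay, though the range must stay wide. For compound 3 the expected value is -30%, within -55% to -5%. The resulting step is expected to be a number 2 percentage points higher from compound 1 to compound 3 (within the scatter).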

Compound 3, a percentage reported as activity, at one concentration (the size of the read-out at that concentration, not a potency): -43%
Estimate against measurement, compound 3: 13 percentage points above; measured number inside the range.
By their numbers in this assay, from the lowest: compound 3; then compound 1; then compound 2.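

In this assay the hydroxy to methoxy change gives a number 11 percentage points lower from compound 1 to compound 3 (beyond the scatter), so at this position the hydrogen on the oxygen is not needed to keep the effect at the concentration tested, and methyl in its place gives a stronger effect. The 3-chloro-5-methoxyphenyl group is thus a second point in the series where one small change moves the number beyond the scatter, alongside the other end of the shared core, where the listed step is a number 17 percentage points higher from compound 1 to compound 2 (beyond the scatter). No measurement in hand gives a reason for the shift at this oxygen.

On these data alone, it remains open whether an ethoxy group, or an amine in place of the oxygen, would continue this trend. As far as these compounds go, it is also open whether methyl on this oxygen has a similar effect when chloro replaces trifluoromethyl at the other end of the shared core.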